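Iodo on the anilino group of compound 3

A few compounds are considered here, and "the series" means these few. Any claim that something is new, unique, unknown or untested is made for them only; others in the source may bear on it.

In a functional assay on MCF7 cells (Homo sapiens) for inhibition, read by sulforhodamine B assay (on this read-out higher numbers stand for weaker inhibition and lower numbers for stronger inhibition), compound 3 `O=C1C=C(Nc2ccccc2)C(=O)c2c1nc1n2[C@H]2OC[C@@H](O)[C@H]2OC1` gives > 4000 nM, which is a limit and not a number. It stands at the limit of > 4000 nM in this assay, at which 1 of the 3 values shown sits. Compound 1 `O=C1C=C(Nc2ccccc2F)C(=O)c2c1nc1n2[C@H]2OC[C@@H](O)[C@H]2OC1` gives 3640 nM, and compound 2 `Cc1ccc(NC2=CC(=O)c3nc4n(c3C2=O)[C@H]2OC[C@@H](O)[C@H]2OC4)cc1` gives 1660 nM.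

Compound 4 `O=C1C=C(Nc2ccc(I)cc2)C(=O)c2c1nc1n2[C@H]2OC[C@@H](O)[C@H]2OC1` has iodo in place of hydrogen on an aromatic carbon, para to a large group, turning phenyl into 4-iodophenyl: iodo in place of hydrogen on an aromatic carbon.

The closest measured change is the loss of methyl from the 4-methylphenyl group of compound 2: an at least 2.4-fold higher number from compound 2 to compound 3 (0.38 log units; beyond the scatter), at least modest. Fluoro gives less to go on: an at least 1.0-fold higher number from compound 1 to compound 3 (0.04 log units; that floor lies within the scatter), a floor within the scatter. The swap of 2-fluorophenyl for 4-methylphenyl is also modest: a 2.2-fold lower number from compound 1 to compound 2 (0.34 log units; beyond the scatter). Read in reverse, the methyl step points to a modest move towards a lower number, but it rests on compound 2 alone, and iodo is untested here.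

The expected change is an at least 2.0-fold lower number from compound 3 to compound 4 (0.30 log units; that floor lies within the scatter). The estimate for compound 4 is 2000 nM, with an expected range of 700 nM to 5500 nM.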

Compound 4, half-maximal inhibitory concentration: 2230 nM
For compound 4 the middle estimate is 1.1-fold (0.05 log units) below the measured one; measured number inside the range.
By their numbers in this assay, from the lowest: compounds 2, 4 and 1 (each within the scatter of the next, the first and the last beyond it). At a limit, above all of these: compound 3.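

Compound 3 remains a limit and not a number in this assay, so iodo in place of hydrogen can be sized only by a floor: the limit of > 4000 nM in this assay, at which 1 of the 4 values shown sits. That floor, an at least 1.7-fold lower number from compound 3 to compound 4 (0.25 log units; that floor lies within the scatter), does not by itself establish a gain from iodo, but para to a large group a second substituent besides methyl now gives a measured value. Iodo and methyl are not separated here, a 1.3-fold higher number from compound 2 to compound 4 (0.13 log units; within the scatter), and 4-iodophenyl is likewise not separated from 2-fluorophenyl, a 1.6-fold lower number from compound 1 to compound 4 (0.21 log units; within the scatter).

As far as these compounds go, the true size of the iodo step stays open, as does whether iodo and methyl act alike for the same reason. From the compounds shown here alone, it is also open whether an amine, a carboxylic acid or a methoxy group at this place would move the number beyond the scatter of compound 2 and compound 4.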